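The source may report more compounds than this note shows. Statements on the series, on what has been measured and on what is new or still open speak of the compounds shown alone.

Compound 1, `CCCCn1nc(C(=O)N[C@H]2COc3ccccc3N(C)C2=S)nc1Cc1ccccc1`, is the starting point of this comparison. In a toxicity assay on HT-29 cells (Homo sapiens) for cytotoxicity (a higher number here means that more compound is tolerated, a lower number that less compound is tolerated), compound 1 reaches only a limit of the test, > 100000 nM. Compound 2, `CN1C(=S)[C@@H](NC(=O)c2nc(Cc3ccccc3)n(CCCCCC#N)n2)COc2ccccc21`, also ends at a limit, giving > 100000 nM in this assay. Compound 3, `CN1C(=S)[C@@H](NC(=O)c2nc(Cc3ccccc3)n(C3CCCCCC3)n2)COc2ccccc21`, likewise stops at a limit of > 100000 nM in this assay. The step that the two limits leave unreadable from compound 1 to compound 2 and the step that the two limits leave unreadable from compound 1 to compound 3 therefore cannot be read, and the same holds for a step that the two limits leave unreadable from compound 2 to compound 3, since all three values sit at the limit of > 100000 nM in this assay, at which 3 of the 3 values shown sit. Compound 4, `CN1C(=S)[C@@H](NC(=O)c2nc(Cc3ccccc3)n(C3CCOC3)n2)COc2ccccc21`, is not yet measured. It differs from compound 1 by oxolan-3-yl in place of butyl on an aromatic nitrogen. The two earlier exchanges on the same aromatic nitrogen, in compounds 2 and 3, produced no readable step, so no movement beyond the scatter is expected in this assay, and compound 4 is expected to sit at the limit as well. The estimate for compound 4 is 150000 nM, with a range from 50000 nM to 500000 nM. This estimate means an expected step that the limit leaves unreadable from compound 1 to compound 4.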

Compound 4, half-maximal cytotoxic concentration: > 100000 nM
Compound 4: no number, only a limit; the forecaster's own chance of this, stated with the estimate: 85%; the middle value does not contradict the limit.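

Compound 4 also ends at a limit in this assay, so its steps to compound 1, compound 2 and compound 3 cannot be read: the limit of > 100000 nM in this assay, at which 4 of the 4 values shown sit. The compounds shown leave open what concentration any of them fails to tolerate, and whether the group on the aromatic nitrogen matters in this assay at all.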